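The compounds below may be only part of what the source reports. "The series", "measured", "known", "first", "only" and "open" are said of these compounds alone.

Compound 1 `Fc1ccc(Nc2nc3nonc3nc2Nc2ccccc2F)cc1` is the weaker of the two compounds measured in an assay on mitochondria from L6 cells (Rattus norvegicus) for activation, with a stated time of 90 min (a lower number here means that less compound is needed, a higher number that more compound is needed for the effect), where compound 1 gives 2300 nM. For the measured compounds named here, the only comparison so far is with compound 2 `Fc1ccccc1Nc1nc2nonc2nc1Nc1ccc(C(F)(F)F)cc1`, which in this assay gives 270 nM; the single change of an 8.5-fold lower number from compound 1 to compound 2 (0.93 log units; beyond the scatter) shows that altering the group on the 4-fluorophenyl ring can move the number considerably.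

Compound 3 `Oc1ccc(F)c(Nc2nc3nonc3nc2Nc2ccccc2F)c1` has not been measured. It differs from compound 1 at the same ring, but in a different way: 2-fluoro-5-hydroxyphenyl in place of 4-fluorophenyl on a nitrogen on an aromatic ring. Going by the values given here, no measured step tests this particular change, so the step from compound 2 only indicates that the ring is sensitive, not in which direction a hydroxyl and a relocated fluorine will push. The expectation is therefore a step of a 1.5-fold lower number from compound 1 to compound 3 (0.19 log units; within the scatter) from compound 1, with wide uncertainty. Compound 3 is estimated at 1500 nM, in a range from 350 nM to 6500 nM.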

Compound 3, half-maximal effective concentration: 30000 nM
Compound 3: middle estimate off by 20-fold (1.30 log units), on the low side, and the stated range ends below it.
By their numbers in this assay, from the lowest: compound 2; then compound 1; then compound 3.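

In this assay, the group on this nitrogen can push the number up as well as down: a 13-fold higher number from compound 1 to compound 3 (1.12 log units; beyond the scatter) accompanies 2-fluoro-5-hydroxyphenyl in place of 4-fluorophenyl, whereas an 8.5-fold lower number from compound 1 to compound 2 (0.93 log units; beyond the scatter) runs the other way. This position therefore does more than accept a range of aromatic groups with small shifts, and one replacement here means that much more compound is needed for the effect. Nothing given here accounts for this rise in the number.

Still open, going by these compounds, is whether the hydroxyl, the new place of the fluorine, or the two together carry this step. Also open, on these data alone, is how the number would respond to a methoxy group or an amine in place of that hydroxyl on the same ring.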